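The source may hold more compounds than are shown below. What is called first, only, known or untested is meant among the compounds shown, and "the series" means these compounds.

Going by the values given here, compound 1 `CCCCCCC(=O)O[C@H](CC=C(C)C)C1=CC(=O)c2c(O)ccc(O)c2C1=O` is the first of two measured compounds; in an assay on HeLa cells for inhibition of DNA topoisomerase 1 (Homo sapiens) (a higher number here means a weaker inhibitor, a lower number a stronger inhibitor), compound 1 gives 625000 nM. Compound 2 `CC(C)=CC[C@@H](OC(=O)/C=C(C)\C=C\C=C(C)\C=C\C1=C(C)CCCC1(C)C)C1=CC(=O)c2c(O)ccc(O)c2C1=O` is the second. In this assay compound 2 reaches only > 625000 nM, which is a limit of the assay and not a number, and compound 2 is counted in the limit of > 625000 nM in this assay, at which 1 of the 2 values shown sits. Compound 3 `CC(C)=CC[C@@H](OC(=O)/C=C(C)/C=C/C=C(C)/C=C/C1=C(C)CCCC1(C)C)C1=CC(=O)c2c(O)ccc(O)c2C1=O` comes from compound 2 by a single change: the two compounds have the same atoms and bonds and differ only in configuration as drawn: 1 of 5 stereo elements differ; a double bond is drawn Z in compound 2 and E in compound 3. Among the compounds with values here, no measured step of this kind exists here, so the expected step from compound 2 to compound 3 in this assay is a step that the limit leaves unreadable from compound 2 to compound 3, none beyond the scatter. Compound 3 is therefore expected near 900000 nM, between 400000 nM and 2000000 nM, most likely again as a limit only.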

Compound 3, half-maximal inhibitory concentration: > 625000 nM
Compound 3: only a limit was reported (the forecaster's own chance of this, stated with the estimate: 75%); the middle value does not contradict the limit.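

Compound 2 and compound 3 both sit at a limit of the assay and not at a number, so no step between them can be read: the limit of > 625000 nM in this assay, at which 2 of the 3 values shown sit.

In this assay the compounds shown leave open whether the Z or the E double bond makes any difference to inhibition.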